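This account rests on a few compounds, and the source may have more. Where it says the series, first, only, none or still open, it means among the compounds named here.

Three compounds with a shared core have been measured in a functional assay on MCF7 cells (Homo sapiens) for inhibition, read by sulforhodamine B assay, with a stated time of 48 h; a lower number here means a stronger inhibitor of growth, a higher number a weaker inhibitor of growth:

compound 1, `COc1cc(-c2nn(-c3cccc(NC(=O)c4cccc(C(F)(F)F)c4)c3)cc2-c2ccncc2)ccc1Cl`, gives 1430 nM;
compound 2, `COc1cc(-c2nn(-c3cccc(NC(=O)Nc4ccc(Cl)c(Cl)c4)c3)cc2-c2ccncc2)ccc1Cl`, gives 945 nM;
compound 3, `COc1cc(-c2nn(-c3cccc(NC(=O)Nc4ccc(Cl)c(C(F)(F)F)c4)c3)cc2-c2ccncc2)ccc1Cl`, gives 919 nM.

Compound 3 has the lowest of the three numbers, but its neighbours sit close: the step from compound 2 to compound 3 is a 1.0-fold lower number from compound 2 to compound 3 (0.01 log units; within the scatter), and the step from compound 1 to compound 3 is a 1.6-fold lower number from compound 1 to compound 3 (0.19 log units; within the scatter), so no ordering among the three can be claimed.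

Compound 4, `COc1cc(-c2nn(-c3cccc(NC(=O)c4ccccc4)c3)cc2-c2ccncc2)ccc1Cl`, has not yet been measured. It differs from compound 3 in one place: phenyl in place of (4-chloro-3-(trifluoromethyl)phenyl)amino on a carbonyl carbon. Going by the values given here, two measured steps bear on this change, since both turn a carbonyl bearing an aryl group into one bearing an arylamino group: a 1.5-fold lower number from compound 1 to compound 2 (0.18 log units; within the scatter) and a 1.6-fold lower number from compound 1 to compound 3 (0.19 log units; within the scatter). Read in reverse, they suggest that going back to a carbonyl with a direct aryl neighbour should give a somewhat higher number, though one still within the scatter. Among the compounds with values here, no measured pair shows what the loss of the trifluoromethyl group adds, so that part of the change carries no information. Compound 4 is therefore expected to give a number in this assay near that of compound 1, a step of a 1.8-fold higher number from compound 3 to compound 4 (0.27 log units; within the scatter), estimated at 1700 nM with a range from 800 nM to 4000 nM.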

Compound 4, concentration for 50% growth inhibition: 335 nM
Beside the measured number, compound 4's estimate is 5.1-fold (0.71 log units) above it, outside the stated range (below it).
By their numbers in this assay, from the lowest: compound 4; then compounds 3, 2 and 1 (each within the scatter of the next).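

In this assay, the earlier exchanges on the carbonyl carbon stayed within the scatter, whereas plain phenyl there separates clearly from both arylamino groups, with a 2.7-fold lower number from compound 3 to compound 4 (0.44 log units; beyond the scatter) and a 2.8-fold lower number from compound 2 to compound 4 (0.45 log units; beyond the scatter). Going by these compounds alone, the single change on the aryl ring, hydrogen in place of trifluoromethyl, gives a 4.3-fold lower number from compound 1 to compound 4 (0.63 log units; beyond the scatter), so this substituent matters in a way that the exchange of aryl for arylamino on the carbonyl carbon did not reveal among compounds 1, 2 and 3. Nothing available explains why this position responds as it does.

The compounds shown leave open whether unsubstituted phenylamino on the carbonyl carbon would give a number close to that of compound 4 or to those of compound 2 and compound 3. They also leave open whether a single fluorine or a methoxy group on that aromatic carbon would behave like hydrogen or like trifluoromethyl.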